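This account rests on a few compounds, and the source may have more. Where it says the series, first, only, none or still open, it means among the compounds named here.

Measured compounds:
- compound 1, `COC(=O)CN1C(=O)c2ccccc2NC1c1ccccc1`: 930 nM in an assay on mitochondria for inhibition of Amine oxidase [flavin-containing] A (Bos taurus), read by fluorescence, with a stated time of 60 min; on this read-out lower numbers stand for stronger inhibition and higher numbers for weaker inhibition
- compound 2, `COC(=O)CN1C(=O)c2ccccc2NC1c1ccco1`: 44 nM in this assay

For the measured compounds named here, compound 1 stands at the higher of the two numbers in this assay; the nearest measured compound is compound 2, and the single measured step, a 21-fold lower number from compound 1 to compound 2 (1.33 log units; beyond the scatter), concerns the aryl group on the saturated ring carbon and is large.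

Compound 3, `NNC(=O)CCN1C(=O)c2ccccc2NC1c1ccccc1`, keeps the phenyl of compound 1 and changes only the side chain on the amide-type nitrogen: (aminocarbamoyl)methyl in place of methoxycarbonyl on a saturated chain carbon bound to an amide-type nitrogen in a ring. Going by the values given here, no measured step touches this side chain, so the step from compound 2 gives no guide here, and nothing in the data points to a direction for the change. The working expectation is therefore a step within the scatter, and compound 3 is expected to come out at a 1.0-fold lower number from compound 1 to compound 3 (0.01 log units; within the scatter). The estimate for compound 3 in this assay is 900 nM, with a range from 300 nM to 3000 nM.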

Compound 3, half-maximal inhibitory concentration: 16 nM
For compound 3 the middle estimate is 56-fold (1.75 log units) above the measured one; measured number below the stated range.
By their numbers in this assay, from the lowest: compound 3; then compound 2; then compound 1.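

With the phenyl of compound 1 held fixed, the side chain on the amide-type nitrogen proves to be a sensitive position in this assay: a 58-fold lower number from compound 1 to compound 3 (1.76 log units; beyond the scatter) comes from (aminocarbamoyl)methyl in place of methoxycarbonyl. For the compounds shown here, until now the only measured step concerned the aryl group, so this is the first sign that the number also responds to a change at this side chain. The exchange is not a single variable, since cut one bond further out it reads (methoxycarbonyl)methyl to 2-(aminocarbamoyl)ethyl, with a heavy-atom count going from 4 to 5 and nitrogen entering the chain end; no data at hand explain the step.

The compounds shown leave open how much of the step belongs to the longer chain and how much to the end group, a question that a 2-(methoxycarbonyl)ethyl side chain or a carboxylic acid at the same chain end would address. Also open, from the compounds shown here alone, is whether furan-2-yl on the saturated ring carbon and 2-(aminocarbamoyl)ethyl on the ring nitrogen combine in one compound.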